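Three Compounds at the Cytotoxicity Limit, a Fourth Estimated

The source may hold more compounds than are shown below. What is called first, only, known or untested is meant among the compounds shown, and "the series" means these compounds.

Compound 1, `CCCCSc1nc(N)nc2c1ncn2/C=C1/CC1(CO)CO`, gives in an ADME assay on Akata cells (Homo sapiens) for cytotoxicity, with a stated time of 7 days (on this read-out higher numbers stand for lower toxicity in this test and lower numbers for higher toxicity in this test), only a limit: > 20000 nM.
Compound 2, `CCCSc1nc(N)nc2c1ncn2/C=C1/CC1(CO)CO`, gives in this assay only a limit: > 20000 nM.
Compound 3, `COCCOc1nc(N)nc2c1ncn2/C=C1/CC1(CO)CO`, gives in this assay only a limit: > 20000 nM.

Compound 3 thus stands where all three measured compounds stand, as the limit of > 20000 nM in this assay, at which 3 of the 3 values shown sit, shows. The steps a step that the two limits leave unreadable from compound 1 to compound 2, a step that the two limits leave unreadable from compound 1 to compound 3 and a step that the two limits leave unreadable from compound 2 to compound 3 cannot be sized from such limits. Compound 4, `CC(C)Sc1nc(N)nc2c1ncn2/C=C1/CC1(CO)CO`, carries isopropylsulfanyl in place of 2-methoxyethoxy on an aromatic carbon. The two steps that change this same aromatic carbon bear on it, and both are unreadable; the entering isopropylsulfanyl is closer in kind to the butylsulfanyl of compound 1 and the propylsulfanyl of compound 2 than to the 2-methoxyethoxy it replaces. The step that the limit leaves unreadable from compound 3 to compound 4 is expected to remain unreadable, with compound 4 again at the limit. Compound 4 is estimated at 30000 nM, between 15000 nM and 100000 nM.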

Compound 4, half-maximal cytotoxic concentration: > 20000 nM
Compound 4 was reported as a limit (the forecaster's own chance of this, stated with the estimate: 85%); the middle value is on the limit's open side.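

Compound 1, compound 2, compound 3 and compound 4 all sit at one assay limit, so no step among them can be read: the limit of > 20000 nM in this assay, at which 4 of the 4 values shown sit.

On these data alone, whether butylsulfanyl, propylsulfanyl, isopropylsulfanyl and 2-methoxyethoxy differ at all in this assay stays open.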